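A few compounds are considered here, and "the series" means these few. Any claim that something is new, unique, unknown or untested is made for them only; others in the source may bear on it.

Measured compounds in an ADME assay on MRC5 cells (Homo sapiens), read by MTT assay, with a stated time of 72 h; on this read-out lower numbers stand for stronger inhibition and higher numbers for weaker inhibition:
compound 1 `COc1ncnc2c1c(-c1cccs1)cn2[C@@H]1O[C@H](CO)[C@@H](O)[C@H]1O` gives 43200 nM
compound 2 `COc1ncnc2c1c(-c1ccccc1)cn2[C@@H]1O[C@H](CO)[C@@H](O)[C@H]1O` gives > 100000 nM
compound 3 `CNc1ncnc2c1c(I)cn2[C@@H]1O[C@H](CO)[C@@H](O)[C@H]1O` gives > 100000 nM

The value of compound 2 is a limit of this assay, not a number. The value of compound 3 is likewise a limit and not a number. Among the measured compounds shown here, two of the three values therefore sit at the limit of > 100000 nM in this assay, at which 2 of the 3 values shown sit, and compound 3 stands there, with nothing to set it apart from compound 2 and only a bounded gap to compound 1, which is the one compound with a number. For the measured compounds named here, the single step among the measured compounds, an at least 2.3-fold higher number from compound 1 to compound 2 (0.36 log units; beyond the scatter), concerns the group on the five-membered ring and does not touch the group that changes here.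

Compound 4 `COc1ncnc2c1c(I)cn2[C@@H]1O[C@H](CO)[C@@H](O)[C@H]1O` differs from compound 3 in one place: methoxy in place of methylamino on an aromatic carbon. Going by the values given here, no measured step bears on this change. Compounds 1 and 2 both carry the methoxy that enters, one with a number and one at the limit. With compound 3 at the limit, compound 4 is expected to stay near the limit as well, a step of a number no higher from compound 3 to compound 4 (the limit leaves the size open) that is not expected to be readable as beyond the scatter. Compound 4 is estimated at 100000 nM, between 30000 nM and 300000 nM.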

Compound 4, half-maximal inhibitory concentration: 63000 nM
For compound 4 the middle estimate is 1.6-fold (0.20 log units) above the measured one; low and high end bracket the measured number.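

In this assay, methoxy in place of methylamino on the aromatic carbon next to the ring nitrogen gives the iodo series a measured number rather than a limit, with an at least 1.5-fold lower number from compound 3 to compound 4 (0.20 log units; that floor lies within the scatter), although this floor alone does not establish a real difference between the two groups. With methoxy kept at that place, changing the group on the five-membered ring gives an at least 1.5-fold lower number from compound 2 to compound 4 (0.20 log units; that floor lies within the scatter), again with only a floor, and a 1.5-fold higher number from compound 1 to compound 4 (0.16 log units; within the scatter), so iodo and thiophen-2-yl cannot be told apart here, while phenyl may lie further up. The first two steps start from a limit of the assay and not from a number, so their true sizes remain unknown: the limit of > 100000 nM in this assay, at which 2 of the 4 values shown sit.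

The compounds shown leave open how a free amine, a dimethylamino group or an ethoxy group would read at the place next to the ring nitrogen. They also leave open whether methoxy in place of methylamino reads the same when thiophen-2-yl or phenyl replaces iodo on the shared core.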